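The source may hold more compounds than are shown below. What is called first, only, known or untested is meant among the compounds shown, and "the series" means these compounds.

Working notes on the series in an ADME assay on SH-SY5Y cells (Homo sapiens) for cytotoxicity, read by MTT assay, with a stated time of 72 h; a lower number here means a stronger inhibitor, a higher number a weaker inhibitor. The reference is compound 1 (`CN(CCCn1c(=O)oc2ccccc21)Cc1ccccc1`). Compound 1 reads > 100000 nM, and this is a limit of the assay, not a number. Among the measured compounds shown here, the only measured neighbour is compound 2 (`CN(CCCn1c(=O)oc2cc(Br)ccc21)Cc1ccccc1`), and in this assay compound 2 gives 58800 nM. Bromo in place of hydrogen on an aromatic carbon gave an at least 1.7-fold lower number from compound 1 to compound 2 (0.23 log units; that floor lies within the scatter). Compound 3 (`CN(CCCn1c(=O)oc2ccc(Cl)cc21)Cc1ccccc1`) differs from the reference by chloro in place of hydrogen on an aromatic carbon, with chloro in place of hydrogen on an aromatic carbon, meta to a fused ring and para to a fused ring. For the measured compounds named here, the single halogen step bears on this change, but its floor supports only a small expectation: a modestly lower number in this assay, possibly nothing beyond the scatter. The expected size is an at least 1.4-fold lower number from compound 1 to compound 3 (0.15 log units; that floor lies within the scatter). Compound 3 is expected at 70000 nM, with an estimated range of 35000 nM to 100000 nM.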

Compound 3, half-maximal inhibitory concentration: > 100000 nM
Compound 3: a limit, no number (the forecaster's own chance of this, stated with the estimate: 40%); middle value at least 1.4-fold (0.15 log units) away from the limit.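

Compound 1 and compound 3 both stand at a limit rather than a number, so no new step can be read between them: the limit of > 100000 nM in this assay, at which 2 of the 3 values shown sit.

The compounds shown leave open whether chloro in place of hydrogen on an aromatic carbon changes the read-out at all.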